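A few compounds are considered here, and "the series" means these few. Any claim that something is new, unique, unknown or untested is made for them only; others in the source may bear on it.

Series notes. Compound 1 `COc1cc2c(Oc3ccc(NC(=O)c4nn(-c5ccc(Br)cc5)c(=O)c5ccccc45)cc3F)ccnc2cc1OCCCN1CCN(C)CC1` gives 850 nM in a functional assay on HT-29 cells (Homo sapiens) for cytotoxicity, read by MTT assay, with a stated time of 72 h; on this read-out higher numbers stand for weaker inhibition and lower numbers for stronger inhibition. Compound 2 `COc1cc2c(Oc3ccc(NC(=O)c4nn(-c5ccccc5Br)c(=O)c5ccccc45)cc3F)ccnc2cc1OCCCN1CCN(C)CC1` gives 1190 nM in this assay; the change from compound 1 is 2-bromophenyl in place of 4-bromophenyl on an aromatic nitrogen, and the step is a 1.4-fold higher number from compound 1 to compound 2 (0.15 log units; within the scatter). Compound 3 `COc1cc2c(Oc3ccc(NC(=O)c4nn(-c5ccc(Br)cc5)c(=O)c5ccccc45)cc3F)ccnc2cc1OCCCN1CCC(C)CC1` gives 920 nM in this assay; its core differs from that of compound 1 by 4-methylpiperidin-1-yl in place of 4-methylpiperazin-1-yl on a saturated chain carbon, three bonds along the chain from an oxygen on an aromatic ring, a step of a 1.1-fold higher number from compound 1 to compound 3 (0.03 log units; within the scatter). Compound 4 `COc1cc2c(Oc3ccc(NC(=O)c4nn(-c5ccccc5Br)c(=O)c5ccccc45)cc3F)ccnc2cc1OCCCN1CCC(C)CC1`, not yet measured, differs from compound 3 by 2-bromophenyl in place of 4-bromophenyl on an aromatic nitrogen; the surroundings of the place read the same as for compound 1 and compound 2, so this is the same change made on the core of compound 3. The expected step for compound 4 in this assay is a 1.3-fold higher number from compound 3 to compound 4 (0.12 log units; within the scatter), beside the earlier one. This rests on compound 1 and compound 2, whose step is a 1.4-fold higher number from compound 1 to compound 2 (0.15 log units; within the scatter). Compound 4 is estimated at 1200 nM, between 600 nM and 2400 nM.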

Compound 4, half-maximal inhibitory concentration: 950 nM
The estimate for compound 4 lay 1.3-fold (0.10 log units) above the measured number; measured number inside the range.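

In this assay, 2-bromophenyl in place of 4-bromophenyl gives a 1.0-fold higher number from compound 3 to compound 4 (0.01 log units; within the scatter), and this step agrees with the earlier one on the core of compound 1: the same change on two cores in this assay, a 1.4-fold higher number (0.15 log units; within the scatter) from compound 1 to compound 2 and a 1.0-fold higher number (0.01 log units; within the scatter) from compound 3 to compound 4, 1.4-fold (0.13 log units) apart, within the scatter of two such steps
On the core carrying 2-bromophenyl, 4-methylpiperidin-1-yl in place of 4-methylpiperazin-1-yl gives a 1.3-fold lower number from compound 2 to compound 4 (0.10 log units; within the scatter), and this change also carries over: the same change on two cores in this assay, a 1.1-fold higher number (0.03 log units; within the scatter) from compound 1 to compound 3 and a 1.3-fold lower number (0.10 log units; within the scatter) from compound 2 to compound 4, 1.4-fold (0.13 log units) apart, within the scatter of two such steps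
For the compounds shown here, all four steps lie within the scatter, so the agreement shows only that neither change moved the number measurably on these cores; it does not show that a change with a step beyond the scatter would carry over in the same way.

Still open, from the compounds shown here alone, is whether a plain phenyl in place of the bromophenyl would leave the number unmoved. The same holds for a morpholine in place of the 4-methylpiperazin-1-yl.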